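Chloro for methyl on a compound at the limit

This account rests on a few compounds, and the source may have more. Where it says the series, first, only, none or still open, it means among the compounds named here.

Compound 1 `Cc1ccccc1C(=O)Nc1ncc(-c2ccccc2)n1C` gives > 100000 nM
Compound 2 `COc1ccc(-c2cnc(NC(=O)c3cccnc3)n2C)cc1` gives > 100000 nM
Compound 3 `COc1ccc(-c2cnc(NC(=O)c3ccccc3C)n2C)cc1` gives > 100000 nM

In a toxicity assay on THP-1 cells (Homo sapiens) for inhibition (on this read-out higher numbers stand for lower toxicity in this test and lower numbers for higher toxicity in this test), compound 1 gives > 100000 nM and this is a limit, not a number. The other two compounds are no different, as the limit of > 100000 nM in this assay, at which 3 of the 3 values shown sit, shows, so compound 1 cannot be ranked against them.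

Compound 4 `Cn1c(-c2ccccc2)cnc1NC(=O)c1ccccc1Cl` has not yet been measured. It carries chloro in place of methyl on an aromatic carbon, ortho to a large group, as counted in chloro in place of methyl on an aromatic carbon (the 2-methylphenyl of compound 1 becomes 2-chlorophenyl). The measured steps that bear on this change are a step that the two limits leave unreadable from compound 1 to compound 3 and a step that the two limits leave unreadable from compound 2 to compound 3 and neither has a readable size. Neither change brought a compound off the limit.

With compound 1 at > 100000 nM as its limit, no step beyond the scatter is expected in this assay and a further limit is the likeliest report. The estimated result is a number no higher from compound 1 to compound 4 (the limit leaves the size open) and no direction is expected in it. For compound 4 the expected value is 100000 nM within an estimated range of 40000 nM to 200000 nM and a limit remains likely.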

Compound 4, half-maximal cytotoxic concentration: > 50000 nM
Compound 4 was reported as a limit; the forecaster's own chance of this, stated with the estimate: 85%; the middle value is on the limit's open side.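

In this assay compound 4 gives > 50000 nM, which is a limit, not a number. Compound 1 also stands at a limit, and no step can be read between compound 1 and compound 4. The compounds shown leave open how chloro and methyl compare, and what value any of these compounds would reach.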